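The compounds below may be only part of what the source reports. "The series", "measured", "known", "first", "only" and "open" are said of these compounds alone.

Measured so far in an in vitro assay on BHK cells for inhibition of Glucagon receptor (Homo sapiens); a higher number here means a weaker inhibitor, a lower number a stronger inhibitor:
compound 1 `CC(C)c1ccc(NC(=O)N(Cc2ccc(C(=O)NCCC(=O)O)cc2)[C@H]2CC[C@H](C(C)(C)C)CC2)cc1` gives 35 nM;
compound 2 `CC(C)(C)[C@H]1CC[C@H](N(Cc2ccc(C(=O)NCCC(=O)O)cc2)C(=O)Nc2cc(C(F)(F)F)cc(C(F)(F)F)c2)CC1` gives 56 nM;
compound 3 `CCCCC(CC)N(Cc1ccc(C(=O)NCCC(=O)O)cc1)C(=O)Nc1ccc(OC(F)(F)F)cc1` gives 141 nM.

Compound 3 stands highest of the three numbers; compound 2 is its nearest neighbour and compound 1 its furthest, both gaps lying beyond the usual scatter. Compound 4 `CC(C)C1CCC(N(Cc2ccc(C(=O)NCCC(=O)O)cc2)C(=O)Nc2ccc(OC(F)(F)F)cc2)CC1` is not yet measured. It differs from compound 3 by 4-isopropylcyclohexyl in place of 1-ethylpentyl on an amide-type nitrogen. Within the data shown here, compounds 1 and 2 both carry a six-membered non-aromatic ring on this nitrogen and both sit lower than compound 3, so a downward step is expected, though no directly comparable pair of measured compounds exists. The expected step of a 2.8-fold lower number from compound 3 to compound 4 (0.45 log units; beyond the scatter) is modest. Compound 4 is estimated at 50 nM, with a range from 20 nM to 130 nM.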

Compound 4, half-maximal inhibitory concentration: 59 nM
Estimate against measurement, compound 4: 1.2-fold (0.07 log units) below, within the range that was stated.
By their numbers in this assay, from the lowest: compounds 1, 2 and 4 (each within the scatter of the next); then compound 3.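

In this assay, a 2.4-fold lower number from compound 3 to compound 4 (0.38 log units; beyond the scatter) comes with 4-isopropylcyclohexyl in place of 1-ethylpentyl on the amide-type nitrogen, and the rest of the molecule stays the same. Among these compounds, this pair isolates a change at this position, which the earlier compounds, differing in more than one place, could not do. No measurement at hand explains the step.

The pair does not separate the ring from the added carbon atoms. A plain cyclohexyl or a longer open chain on this nitrogen would bear on that question.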